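This account rests on a few compounds, and the source may have more. Where it says the series, first, only, none or still open, it means among the compounds named here.

Working notes on the urea series. Compound 1 `COc1ccc(NC(=O)Nc2cc(C)nc3ccccc23)cc1Cl` gives 26000 nM in an ADME assay on HEK293 cells (Homo sapiens) for cytotoxicity, with a stated time of 72 h; on this read-out lower numbers stand for an effect already at smaller amounts and higher numbers for an effect only at larger amounts of compound. Compound 3 `Cc1cc(NC(=O)Nc2ccc(SC(F)(F)F)cc2)c2ccccc2n1` gives 13000 nM in this assay; the two numbers are within the usual scatter of each other. For compound 2 `CSc1ccccc1NC(=O)Nc1cc(C)nc2ccccc12` only a limit is reported in this assay, > 25000 nM, so no number of its own is available. Compound 2 therefore stands at the edge of the measured range, at the limit where one of the three values sits (the limit of > 25000 nM in this assay, at which 1 of the 3 values shown sits). The unmeasured compound 4 `Cc1cc(NC(=O)Nc2ccccc2F)c2ccccc2n1` differs from compound 2 by fluoro in place of methylsulfanyl on an aromatic carbon. Among the compounds with values here, no measured pair in this set differs in a single place, so no measured step is available as a guide for the change from compound 2 to compound 4. Since all three measured values lie in the same weak region, the step from compound 2 to compound 4 is expected to stay within the scatter in this assay, a number no higher from compound 2 to compound 4 (the limit leaves the size open), with a fair chance that compound 4 again reports only a limit. Compound 4 is estimated at 25000 nM in this assay, within a range of 9000 nM to 70000 nM.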

Compound 4, half-maximal effective concentration: > 25000 nM
Compound 4: a limit, no number; the forecaster's own chance of this, stated with the estimate: 50%; the middle value sits exactly at the limit.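

Compound 2 and compound 4 both report only a limit, so no step can be read for fluoro in place of methylsulfanyl: the limit of > 25000 nM in this assay, at which 2 of the 4 values shown sit.

The compounds shown leave open how far either compound lies past that limit, and whether this change has any effect in this assay.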